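Swapping Heptyl for Octyloxy: How Large a Step?

The source may hold more compounds than are shown below. What is called first, only, known or untested is meant among the compounds shown, and "the series" means these compounds.

In a functional assay on brain (Rattus norvegicus, strain Wistar) for inhibition (a lower number here means a stronger inhibitor, a higher number a weaker inhibitor), two compounds sharing one core have been measured so far. Compound 1 `COc1ccc(-c2c(C)[nH]c(=O)n2C2CCCCC2)cc1` gives 20400 nM, and compound 2 `CCCCCCCc1ccc(-c2c(C)[nH]c(=O)n2C2CCCCC2)cc1` gives 8700 nM, the lower of the two numbers. The next compound, compound 3 `CCCCCCCCOc1ccc(-c2c(C)[nH]c(=O)n2C2CCCCC2)cc1`, differs from compound 2 in one group: octyloxy in place of heptyl on an aromatic carbon. Octyloxy takes the place of heptyl on an aromatic carbon, para to a large group. Among the compounds with values here, only one measured step bears on this change: a 2.3-fold lower number from compound 1 to compound 2 (0.37 log units; beyond the scatter), a modest gain when heptyl replaced methoxy. Within the data shown here, no measured compound yet carries octyloxy, so this single step is a limited guide. A similarly small move toward a lower number is therefore expected, with a 1.5-fold lower number from compound 2 to compound 3 (0.16 log units; within the scatter) as the estimated step. In this assay, compound 3 is estimated at 6000 nM, with an expected range from 2000 nM to 18000 nM.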

Compound 3, half-maximal inhibitory concentration: 8500 nM
Beside the measured number, compound 3's estimate is 1.4-fold (0.15 log units) below it; measured number inside the range.
By their numbers in this assay, from the lowest: compounds 3 and 2 (each within the scatter of the next); then compound 1.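

In this assay, octyloxy in place of heptyl gives a 1.0-fold lower number from compound 2 to compound 3 (0.01 log units; within the scatter), so on this aromatic carbon, para to a large group, the two long chains cannot be told apart. The same compound 3 stands apart from the methoxy compound, with a 2.4-fold lower number from compound 1 to compound 3 (0.38 log units; beyond the scatter), which means that both long chains, one with an oxygen on the aromatic carbon and one without, read alike and both differ from methoxy. Chain length and the oxygen change together between compound 2 and compound 3, so this step cannot separate what each does alone.

No measurement shown offers a reason for these numbers. Still open, from the compounds shown here alone, is whether a mid-length chain such as butyl, a much longer chain such as dodecyl, or an amine at the chain end would move the number at this position.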